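The compounds below may be only part of what the source reports. "The series", "measured", "known", "first", "only" and "open" are said of these compounds alone.

Of the compounds shown here, three have been measured in a functional assay on 786-0 cells (Homo sapiens) for inhibition, read by sulforhodamine B assay, with a stated time of 48 h, tested at 10 uM; a higher number here means a weaker effect of the compound at the concentration tested, a lower number a stronger effect. Compound 1 `COc1cc(Cl)cc(-c2nn(-c3cccc(NC(=O)c4ccc(Cl)c(Cl)c4)c3)cc2-c2ccncc2)c1` gives 74.1%. Compound 2 `O=C(Nc1cccc(-n2cc(-c3ccncc3)c(-c3cc(O)cc(Cl)c3)n2)c1)Nc1ccc(Cl)c(C(F)(F)F)c1` gives -29.8%, the second highest of the three numbers, with compound 1 far above it and compound 3 closest below it. Compound 3 `O=C(Nc1cccc(-n2cc(-c3ccncc3)c(-c3cc(O)cc(Cl)c3)n2)c1)Nc1ccc(Cl)c(Cl)c1` gives -72.1%. For the measured compounds named here, the only single-point step among them is a number 42.3 percentage points lower from compound 2 to compound 3 (beyond the scatter), which concerns the far end of the urea and not the part of the molecule that changes here.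

Compound 4 `COc1cc(Cl)cc(-c2nn(-c3cccc(NC(=O)Nc4ccc(Cl)c(C(F)(F)F)c4)c3)cc2-c2ccncc2)c1` differs from compound 2 by methyl in place of hydrogen on an oxygen on an aromatic ring. Going by the values given here, no measured step isolates this change. Compound 1 carries the same methoxy group but also differs from compound 2 in a second place, so its value and that of compound 2 show only that the two together are very far apart. Among the compounds with values here, the step to compound 4 is therefore expected from no direct precedent. For compound 4 the estimate is 0%, within a range from -40% to 45%. This estimate means an expected step of a number 29.8 percentage points higher from compound 2 to compound 4 (beyond the scatter), beyond the scatter but much smaller than the gap to compound 1.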

Compound 4, a percentage reported as activity, at one concentration (the size of the read-out at that concentration, not a potency): -4.76%
For compound 4 the middle estimate is 4.8 percentage points above the measured one; low and high end bracket the measured number.
By their numbers in this assay, from the lowest: compound 3; then compound 2; then compound 4; then compound 1.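

In this assay, capping the oxygen with methyl, hydroxy to methoxy on the 3-chloro-5-hydroxyphenyl ring, gives a number 25 percentage points higher from compound 2 to compound 4 (beyond the scatter), so the effect at the tested concentration weakens modestly, and the free hydrogen on that oxygen is not essential for keeping a low number. With the methoxy held constant, the change on the carbonyl carbon gives a number 78.9 percentage points lower from compound 1 to compound 4 (beyond the scatter), a large step that shows most of the wide gap between compound 1 and compound 2 sits at that end of the molecule and not at the oxygen. Nothing available here explains either step.

On these data alone, it remains open whether methyl on this oxygen would cost a similar amount with the 3,4-dichlorophenyl urea of compound 3. An ethoxy group or an amine at the same place would show how much this position tolerates.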